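Quinazoline thioacetamides: 2,4-dichlorophenyl for 3-chloro-4-fluorophenyl

The compounds below may be only part of what the source reports. "The series", "measured", "known", "first", "only" and "open" are said of these compounds alone.

Measured compounds, in a functional assay on MGC-803 cells (Homo sapiens) for inhibition, read by MTT assay, with a stated time of 72 h; a lower number here means a stronger inhibitor, a higher number a weaker inhibitor:
- compound 1 `O=C(CSc1nc(Nc2ccccc2)c2ccccc2n1)Nc1ccc(Cl)cc1Cl`: 12300 nM
- compound 2 `O=C(CSc1nc(Nc2ccccc2)c2ccccc2n1)Nc1ccc(F)c(Cl)c1`: 20900 nM
- compound 3 `C=CC(=O)Nc1cccc(NC(=O)CSc2nc(Nc3ccc(F)c(Cl)c3)c3ccccc3n2)c1`: 7850 nM

Compounds 1 and 2 share one core and differ only in the group on the amide-type nitrogen; the change is 2,4-dichlorophenyl in place of 3-chloro-4-fluorophenyl on an amide-type nitrogen, and the step it made is a 1.7-fold lower number from compound 2 to compound 1 (0.23 log units; within the scatter). The two values therefore cannot be ordered against each other. Compound 3 carries a different core, and the difference between the core of compound 3 and the core of compound 2 is not broken down here; compound 3 stands at the lowest of the three numbers, with the gap to compound 1 within the scatter and the gap to compound 2 beyond it.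

Compound 4 `C=CC(=O)Nc1cccc(NC(=O)CSc2nc(Nc3ccc(Cl)cc3Cl)c3ccccc3n2)c1` is not yet measured. It relates to compound 3 by 2,4-dichlorophenyl in place of 3-chloro-4-fluorophenyl on a nitrogen on an aromatic ring. Within the data shown here, this is the same kind of change as the one from compound 2 to compound 1, but the place is not the same: there the nitrogen was an amide-type nitrogen whose other neighbour is a carbonyl carbon, here it is a nitrogen on an aromatic ring whose other neighbour is an aromatic carbon. Among the measured compounds shown here, since the only measured instance, the step from compound 2 to compound 1, stayed within the scatter, the expectation for compound 4 is a step of about a 1.4-fold lower number from compound 3 to compound 4 (0.15 log units; within the scatter), a small move if any. Compound 4 is estimated at 5500 nM, with the range 2500 nM to 14000 nM, resting on compound 3 at 7850 nM and on the small size of the earlier step.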

Compound 4, half-maximal inhibitory concentration: 12100 nM
Compound 4: middle estimate off by 2.2-fold (0.34 log units), on the low side; the measured number falls inside the stated range.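

In this assay, placing 2,4-dichlorophenyl for 3-chloro-4-fluorophenyl on a nitrogen on an aromatic ring gives a 1.5-fold higher number from compound 3 to compound 4 (0.19 log units; within the scatter), so compound 3 and compound 4 cannot be ordered against each other. Among these compounds, this does not show that the change has a fixed effect that carries from core to core, nor that its effect depends on the core: neither step can be ordered, their printed directions carry no weight, and only two cores and two places of attachment are involved. What can be said is limited to these two pairs, where the change left the numbers within the scatter on the core of compound 2 and on the core of compound 3, and the steps themselves cannot be told apart: the same change on two cores in this assay, a 1.7-fold lower number (0.23 log units; within the scatter) from compound 2 to compound 1 and a 1.5-fold higher number (0.19 log units; within the scatter) from compound 3 to compound 4, 2.6-fold (0.42 log units) apart, within the scatter of two such steps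

The compounds shown leave open whether any substituent on this phenyl ring would move the number beyond the scatter, since only these two halogenated patterns appear; a methoxy group, a carboxylic acid or an amine in that place would test this. They also leave open how the change behaves in any other cell line or assay, as all four compounds are compared in this single read-out.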